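This account rests on a few compounds, and the source may have more. Where it says the series, first, only, none or still open, it means among the compounds named here.

Of the compounds shown here, three have been measured in an ADME assay on MT2 cells (Homo sapiens) for cytotoxicity, read by XTT assay, with a stated time of 4 days; a higher number here means that more compound is tolerated, a lower number that less compound is tolerated.

Compound 1 `O=C(O)c1ccc(N2C(=O)C=CC2=O)cc1O` gives > 400000 nM, which is a limit of the assay and not a number.
Compound 2 `c1cc(-c2nnn[nH]2)cc(-n2cccc2)c1` gives 436000 nM.
Compound 3 `COC(=O)c1ccc(N2C(=O)C=CC2=O)cc1O` gives 66200 nM.

From the compounds shown here alone, compound 1 thus stands only at the edge of what this assay can report: one of the three values sits at the limit of > 400000 nM in this assay, at which 1 of the 3 values shown sits, so its true number is unknown. Compound 2 stands close to that same region, and compound 3 is the only one with a clearly lower number. Going by the values given here, the one measured step, an at least 6.0-fold lower number from compound 1 to compound 3 (0.78 log units; beyond the scatter), shows that masking the acid as its methyl ester makes the cells tolerate less of the compound.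

Compound 4 `O=C(O)c1ccc(N2C(=O)C=CC2=O)cc1` is the next compound. hydrogen in place of hydroxy on an aromatic carbon The carboxylic acid of compound 1 is kept. Among the compounds with values here, no measured step covers the loss of a hydroxy group, so the change from compound 1 to compound 3 does not bear directly on it and gives no direction to expect. Because compound 1 reaches > 400000 nM, compound 4 is expected to be tolerated to a similar degree, with a number no higher from compound 1 to compound 4 (the limit leaves the size open) likely within the scatter. The estimate for compound 4 is therefore 400000 nM, between 150000 nM and 1000000 nM.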

Compound 4, half-maximal cytotoxic concentration: > 400000 nM
Compound 4: no number, only a limit; the forecaster's own chance of this, stated with the estimate: 60%; the middle value sits exactly at the limit.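

In this assay compound 4 gives > 400000 nM, which is a limit of the assay and not a number. Compound 1 also sits at a limit, so no step between compound 1 and compound 4 can be read: the limit of > 400000 nM in this assay, at which 2 of the 4 values shown sit.

The compounds shown leave open whether hydrogen in place of hydroxy changes the tolerated amount at all.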